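Adding a ring to the side chain of compound 1

This account rests on a few compounds, and the source may have more. Where it says the series, first, only, none or still open, it means among the compounds named here.

Compound 1 `CC(C)C(C)/N=c1\c(O)c(O)\c1=N/c1ccc(C#N)cc1`: 1900 nM
Compound 2 `C[C@H](/N=c1\c(O)c(O)\c1=N/c1ccc(C#N)cc1)C1CCCCC1`: > 30000 nM (a limit of the assay)

For the measured compounds named here, in a functional assay for inhibition, with Rattus norvegicus as the target (a higher number here means a weaker inhibitor, a lower number a stronger inhibitor), compound 1 gives 1900 nM, the only exact number so far and the stronger result of the two. The value for compound 2 is a limit, not a number.

Compound 3 `Cc1ccc(C(C)/N=c2\c(O)c(O)\c2=N/c2ccc(C#N)cc2)cc1` has not been measured: 4-methylphenyl in place of isopropyl on a saturated chain carbon bound to a double-bonded nitrogen and a saturated chain carbon. Going by the values given here, one measured step bears on it, an at least 15-fold higher number from compound 1 to compound 2 (1.19 log units; beyond the scatter), a large loss that also put a ring-bearing group on the chain. A weaker result is therefore expected, though the aromatic ring may cost less. The expected step is a 4.2-fold higher number from compound 1 to compound 3 (0.62 log units; beyond the scatter). For compound 3 the estimate is 8000 nM, within an expected range of 1800 nM to 30000 nM.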

Compound 3, half-maximal inhibitory concentration: > 30000 nM
Compound 3 ended at the assay's limit (the forecaster's own chance of this, stated with the estimate: 30%); at least 3.7-fold (0.57 log units) between middle value and limit.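

Replacing isopropyl with 4-methylphenyl gives an at least 15-fold higher number from compound 1 to compound 3 (1.19 log units; beyond the scatter), so on this chain carbon an aromatic ring is as poorly tolerated as the saturated ring of compound 2. The full size of the loss remains unknown, and compound 2 and compound 3 cannot be ranked against each other because both reach the same assay limit: the limit of > 30000 nM in this assay, at which 2 of the 3 values shown sit.

Still open, as far as these compounds go, is whether the ring itself or simply the added heavy atoms cost the activity. A small cyclopropyl ring or a ringless tert-butyl group would help separate the two.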